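A few compounds are considered here, and "the series" means these few. Any claim that something is new, unique, unknown or untested is made for them only; others in the source may bear on it.

Working notes on the series.

Compound 1 `CC(C)OC(=O)Nc1c(C(O)(C(F)(F)F)C(F)(F)F)ccc2ccccc12` gives 1160 nM in an assay on LtK cells with ATP-sensitive inward rectifier potassium channel 11 (Homo sapiens) as the target; on this read-out lower numbers stand for an effect already at smaller amounts and higher numbers for an effect only at larger amounts of compound. Compound 2 `O=C(Nc1c(C(O)(C(F)(F)F)C(F)(F)F)ccc2ccccc12)c1cccc(Cl)c1` gives 98 nM in this assay, the step of a 12-fold lower number from compound 1 to compound 2 (1.07 log units; beyond the scatter). Compound 3 `O=C(Nc1c(C(O)(C(F)(F)F)C(F)(F)F)ccc2ccccc12)c1ccc(Cl)cc1` gives 570 nM in this assay; against compound 1 the step is a 2.0-fold lower number from compound 1 to compound 3 (0.31 log units; beyond the scatter), against compound 2 it is a 5.8-fold higher number from compound 2 to compound 3 (0.76 log units; beyond the scatter). Among the three numbers compound 3 thus stands second highest, nearer to compound 1 than to compound 2.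

Compound 4 `O=C(Nc1c(C(O)(C(F)(F)F)C(F)(F)F)ccc2ccccc12)c1ccco1` is not yet measured. Its change from compound 3 is furan-2-yl in place of 4-chlorophenyl on a carbonyl carbon. All three measured steps are replacements on the same carbonyl carbon, so they bear on it in kind, but none introduces a furan-2-yl, and the spread of their sizes, from a 2.0-fold lower number from compound 1 to compound 3 (0.31 log units; beyond the scatter) to a 12-fold lower number from compound 1 to compound 2 (1.07 log units; beyond the scatter), shows the group on this carbonyl carbon matters in this assay without fixing a direction. A modest step is expected from compound 3 to compound 4 in this assay, about a 1.2-fold higher number from compound 3 to compound 4 (0.09 log units; within the scatter), with the direction uncertain. Compound 4 is therefore estimated at 700 nM in this assay, expected within 200 nM to 2500 nM.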

Compound 4, half-maximal effective concentration: 9 nM
Compound 4: the middle estimate sits 78-fold (1.89 log units) above what was measured; the whole stated range lies above it.
By their numbers in this assay, from the lowest: compound 4; then compound 2; then compound 3; then compound 1.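

In this assay furan-2-yl gives the largest step yet seen on this carbonyl carbon, a 63-fold lower number from compound 3 to compound 4 (1.80 log units; beyond the scatter) and it also leads the other two groups, with an 11-fold lower number from compound 2 to compound 4 (1.04 log units; beyond the scatter) and a 130-fold lower number from compound 1 to compound 4 (2.11 log units; beyond the scatter) as the remaining steps. The earlier compounds shown here placed only isopropoxy and the two chlorophenyl groups here, whereas compound 4 now shows that a five-membered aromatic ring with one hetero atom can take the series well past all three. Nothing at hand gives a reason for the size of this change.

This single change swaps ring size, the ring oxygen and the chlorine at once, so the compounds shown do not separate them. From the compounds shown here alone, whether thiophen-2-yl, furan-3-yl, unsubstituted phenyl or saturated tetrahydrofuran-2-yl would hold the low number remains open.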